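Shrinking the ether-linked ring system of compound 2

The source may report more compounds than this note shows. Statements on the series, on what has been measured and on what is new or still open speak of the compounds shown alone.

Going by the values given here, compound 2 `COc1ccc2nc(COc3ccc4c(c3)c(SC(C)(C)C)c(CC(C)(C)C(=O)O)n4Cc3ccc(Cl)cc3)sc2c1` is one of two compounds measured in a functional assay for inhibition, with Homo sapiens as the target; a lower number here means a stronger inhibitor, a higher number a weaker inhibitor. In this assay compound 2 gives 8 nM, the higher of the two numbers. Among the compounds with values here, its only neighbour is compound 1 `CC(C)(C)Sc1c(CC(C)(C)C(=O)O)n(Cc2ccc(Cl)cc2)c2ccc(OCc3ccc4cc(F)ccc4n3)cc12`, which in this assay gives 2 nM; the change from one bicyclic ring system to another on the saturated chain carbon bound to the ring oxygen is a 4.0-fold higher number from compound 1 to compound 2 (0.60 log units; beyond the scatter).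

Compound 3 `CC(COc1ccc2c(c1)c(SC(C)(C)C)c(CC(C)(C)C(=O)O)n2Cc1ccc(Cl)cc1)c1ccccn1` takes the next step from compound 2. The difference is 1-(pyridin-2-yl)ethyl in place of 6-methoxy-1,3-benzothiazol-2-yl on a saturated chain carbon bound to an oxygen on an aromatic ring. This is a larger change than the earlier one: the two fused rings give way to a single ring carrying one nitrogen, and the linking carbon now bears a methyl group. Within the data shown here, only the step from compound 1 to compound 2 bears on it, and it showed that swapping the group at this position can shift the readout by a modest but real amount. Compound 3 is therefore expected to show a further weakening, estimated as a 5.0-fold higher number from compound 2 to compound 3 (0.70 log units; beyond the scatter). For compound 3 the estimated value is 40 nM, with a likely range from 8 nM to 200 nM.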

Compound 3, half-maximal inhibitory concentration: 4 nM
Compound 3: middle estimate off by 10-fold (1.00 log units), on the high side; measured number below the stated range.
By their numbers in this assay, from the lowest: compounds 1, 3 and 2 (each within the scatter of the next, the first and the last beyond it).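

In this assay, the single-ring 1-(pyridin-2-yl)ethyl group cannot be told apart from either fused-ring group: the step is a 2.0-fold lower number from compound 2 to compound 3 (0.30 log units; within the scatter), and the comparison with the other fused-ring compound is a 2.0-fold higher number from compound 1 to compound 3 (0.30 log units; within the scatter). At this place, on a saturated chain carbon bound to an oxygen on an aromatic ring, a second fused ring is therefore not required for a number in this low range, and neither the methoxy group nor the fluorine is needed, at least in these three compounds. No measurement here accounts for this tolerance of a group with fewer heavy atoms and fewer hydrogen-bond acceptors.

Going by these compounds, compound 3 brings in the single ring and the methyl group on the linking carbon together, so their separate contributions remain unknown, and the plain pyridin-2-ylmethyl group would be the comparison that could separate them. The compounds shown also leave open whether the ring nitrogen matters, which a 1-phenylethyl group in the same place would test.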